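The compounds below may be only part of what the source reports. "The series", "measured", "known", "first", "only" and "open" are said of these compounds alone.

In an in vitro functional assay on 1321-N1 cells for antagonist activity at transient receptor potential cation channel subfamily V member 1 (Homo sapiens), read by FLIPR and calcium flux (on this read-out lower numbers stand for lower potency and higher numbers for higher potency (the scale is a negative logarithm)), compound 1, with the structure `N#Cc1ccc(-c2ccc(C(=O)Nc3ccc4cccnc4c3)cn2)cc1`, is known only by a limit: it gives < 6.6. Two related compounds share its core. Compound 2, `N#Cc1ccc(C(=O)Nc2ccc3cccnc3c2)cn1`, also stops at a limit in this assay, giving < 6.7. Compound 3, `O=C(Nc1ccc2cccnc2c1)c1ccc(Cl)nc1`, likewise gives a limit of < 6.7 in this assay. Each of these values being a limit, the steps between them cannot be read: a step that the two limits leave unreadable from compound 1 to compound 2, a step that the two limits leave unreadable from compound 1 to compound 3 and a step that the two limits leave unreadable from compound 2 to compound 3. The whole picture is summed up by the limit of < 6.6 in this assay, at which 1 of the 3 values shown sits, and (the limit of < 6.7 in this assay, at which 2 of the 3 values shown sit).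

Compound 4, with the structure `O=C(Nc1ccc2cccnc2c1)c1ccc(-c2ccc(C(F)(F)F)cc2)nc1`, differs from compound 1 in one place: trifluoromethyl in place of cyano on an aromatic carbon. Among the compounds with values here, none of the measured steps touches this change directly, and the two that replace the whole 4-cyanophenyl group remain unreadable, so no step size can be carried over. What can be said is that every compound in this group so far has stayed under its limit. Compound 4 is therefore expected to sit near that same level. The step that this estimate means is a step that the limit leaves unreadable from compound 1 to compound 4, an expected rather than a measured figure. The estimate for compound 4 in this assay is 6.3, with a range from 5.5 to 7.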

Compound 4, negative logarithm of the antagonist equilibrium constant: 7.3
Estimate against measurement, compound 4: 1.00 log units below; measured number outside the range, above it.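

Within the data shown here, putting trifluoromethyl in place of cyano, on an aromatic carbon para to a large group, gives a number at least 0.70 log units higher from compound 1 to compound 4 (beyond the scatter), the first step that can be read at all, as those among compounds 1, 2 and 3 cannot be. Among these compounds, the size of this step is a minimum and not an exact figure, and compound 4 is the first compound here with a true number in this assay, showing that potency at this receptor does respond to the group at this one position while the shared core stays the same. The line of data gives no reason why trifluoromethyl has this effect, and nothing measured here bears on the cause.

Going by these compounds, only these two groups can be compared at this position, so it remains open how a methoxy group, an amine or a carboxylic acid would behave there. It is also unknown whether the effect depends on trifluoromethyl itself or would appear with other groups of similar size, such as a chlorine atom or a tert-butyl group, on that same aromatic carbon.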